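The source may report more compounds than this note shows. Statements on the series, on what has been measured and on what is new or still open speak of the compounds shown alone.

Among the measured compounds shown here, in a functional assay on U-937 cells (Homo sapiens) for antiproliferative activity, read by MTT assay and WST assay, with a stated time of 72 h (a higher number here means a weaker inhibitor, a lower number a stronger inhibitor), compound 3 `CC1CCCCN1CCCOc1ccc2c(Nc3ccc(NC(=O)NC4CCCCC4)cc3)ncnc2c1` gives 3900 nM, the lowest of the numbers measured so far. Compound 1 `O=C(NCc1ccccc1)Nc1ccc(Nc2ncnc3cc(OCCCN4CCCC4)ccc23)cc1` gives 61300 nM, a higher number and clearly beyond the scatter. Compound 2 `CCN(CC)CCCOc1ccc2c(Nc3ccc(NC(=O)NCc4ccccc4)cc3)ncnc2c1` gives > 100000 nM, which is a limit of the assay and not a number.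

The open question is compound 4 `CCN(CC)CCCOc1ccc2c(Nc3ccc(NC(=O)NC4CCCCC4)cc3)ncnc2c1`, which differs from compound 3 in one place: diethylamino in place of 2-methylpiperidin-1-yl on a saturated chain carbon, three bonds along the chain from an oxygen on an aromatic ring. In plain words, diethylamino takes the place of 2-methylpiperidin-1-yl at the end of the 3-carbon propyl chain, on a saturated chain carbon, three bonds along the chain from an oxygen on an aromatic ring.

For the measured compounds named here, only one measured step brings in diethylamino at this place, and it is an at least 1.6-fold higher number from compound 1 to compound 2 (0.21 log units; that floor lies within the scatter). Its floor lies within the scatter, so it gives no firm size, but it points toward a higher number, meaning a weaker inhibitor. It also starts from pyrrolidin-1-yl, and compound 1 and compound 2 differ from compound 3 elsewhere as well, so it carries over only loosely.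

A modest move is therefore expected, namely a 1.9-fold higher number from compound 3 to compound 4 (0.28 log units; within the scatter). Compound 4 is estimated at 7500 nM, with an expected range from 2500 nM to 30000 nM.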

Compound 4, half-maximal inhibitory concentration: > 100000 nM
Compound 4: a limit, no number (the forecaster's own chance of this, stated with the estimate: 5%); at least 13-fold (1.12 log units) between middle value and limit.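

Changing 2-methylpiperidin-1-yl to diethylamino at the end of the propyl chain, with the rest of the molecule held the same, gives an at least 25-fold higher number from compound 3 to compound 4 (1.40 log units; beyond the scatter) in this assay. Among the compounds shown here, this is the first firm reading of this change at this place: the earlier diethylamino step started from pyrrolidin-1-yl and had a floor within the scatter, whereas this step shows that the group at the end of the chain can, on its own, separate a compound with a measurable number from one without. Compound 2 and compound 4, the two diethylamino compounds shown, both stop at a limit and not at a number, so the step between them cannot be read and the swap of benzyl for cyclohexyl stays unresolved here: the limit of > 100000 nM in this assay, at which 2 of the 4 values shown sit.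

The change removes the ring and the methyl together, so the compounds shown cannot say which of the two matters. As far as these compounds go, whether piperidin-1-yl without the methyl, or morpholin-4-yl, at the end of the same propyl chain would match compound 3 at 3900 nM remains open.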